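The source may report more compounds than this note shows. Statements on the series, on what has been measured and on what is new or still open speak of the compounds shown alone.

Measured in a functional assay on DU-145 cells (Homo sapiens) for cytotoxicity, read by sulforhodamine B assay, with a stated time of 3 days; a lower number here means that less compound is needed, a higher number that more compound is needed for the effect:

compound 1 `COC(=O)c1c(C)coc1-c1ccc2c(c1OC)CCCC2(C)C` gives 33.5 uM
compound 2 `Cc1coc(-c2ccc3c(c2O)CCCC3(C)C)c1C(=O)O` gives 3 uM

In this small set, a lower number means that less compound is needed for the effect. Compound 2, at 3 uM, holds the lower of the two numbers, and the gap up to compound 1 lies beyond the usual scatter of repeat measurements.

Compound 3 `COc1c(-c2occ(C)c2C(=O)O)ccc2c1CCCC2(C)C` is compound 2 with a single change methyl in place of hydrogen on an oxygen on an aromatic ring, so that hydroxy becomes methoxy.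

Within the data shown here, no pair of measured compounds shows this change on its own, so the expectation rests on thin evidence. Compound 1 also carries the methoxy and gives 33.5 uM, which makes a move toward higher numbers seem likelier than a move the opposite way. That compound is not a clean comparison, however, so a moderate rise is expected in this assay, probably beyond the scatter, though no real change cannot be ruled out.

The expected move is a 3.3-fold higher number from compound 2 to compound 3 (0.52 log units; beyond the scatter). Compound 3 is estimated at 10 uM, with an expected range of 3 uM to 35 uM.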

Compound 3, concentration for half-maximal effect: 34.1 uM
Compound 3: the middle estimate sits 3.4-fold (0.53 log units) below what was measured; the measured number falls inside the stated range.
By their numbers in this assay, from the lowest: compound 2; then compounds 1 and 3 (each within the scatter of the next).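

In this assay, among these compounds, methyl in place of hydrogen on the oxygen on the aromatic ring, so that hydroxy becomes methoxy, gives an 11-fold higher number from compound 2 to compound 3 (1.06 log units; beyond the scatter), and this is the first time the change can be read on its own, as a large step in the direction of needing more compound. With the methoxy in place, the other single change, hydrogen in place of methyl on an oxygen next to a carbonyl group, gives a 1.0-fold higher number from compound 1 to compound 3 (0.01 log units; within the scatter), so in this pair that swap leaves the number within the scatter, and of the two single changes shown, only the one at the aromatic oxygen moves the number beyond it. Nothing measured here offers an explanation for the size of the step from hydroxy to methoxy.

The compounds shown leave open whether the methyl on the oxygen next to the carbonyl group would also make no difference with the hydroxy in place, since the one pair that reads this change carries the methoxy. They also leave open how the number would respond at the aromatic position to a longer chain such as ethoxy, or to an amine in place of the hydroxy.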